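Shortening a selenocyanate chain on an ester-linked quinazoline

The source may hold more compounds than are shown below. What is called first, only, known or untested is meant among the compounds shown, and "the series" means these compounds.

Compound 1, `COc1ccc(N(C)c2nc(C)nc3ccccc23)cc1OCCC[Se]C#N`, gives 815 nM in a functional assay on MDA-MB-231 cells (Homo sapiens) for inhibition, read by MTT assay, with a stated time of 48 h; on this read-out higher numbers stand for weaker inhibition and lower numbers for stronger inhibition.
Compound 2, `COc1ccc(N(C)c2nc(C)nc3ccccc23)cc1OCCCC[Se]C#N`, gives 1350 nM in this assay.
Compound 3, `COc1ccc(N(C)c2nc(C)nc3ccccc23)cc1C(=O)OCCCCCC[Se]C#N`, gives 2210 nM in this assay.

Compounds 1 and 2 share a core and differ only in the chain: a group of 3 heavy atoms (1 carbon, 1 nitrogen, 1 selenium; no ring) in place of a group of 4 heavy atoms (2 carbon, 1 nitrogen, 1 selenium; no ring), on a saturated chain carbon, three bonds along the chain from an oxygen on an aromatic ring. That change gave a 1.7-fold lower number from compound 2 to compound 1 (0.22 log units; within the scatter). Compound 3 is built on a different core; how its core differs from that of compound 2 is not broken down here. Among the three measured compounds, compound 3 has the highest number, with compound 2 nearest and compound 1 furthest away.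

Compound 4, `COc1ccc(N(C)c2nc(C)nc3ccccc23)cc1C(=O)OCCCCC[Se]C#N`, has not yet been measured in this assay. It differs from compound 3 as follows: a group of 3 heavy atoms (1 carbon, 1 nitrogen, 1 selenium; no ring) in place of a group of 4 heavy atoms (2 carbon, 1 nitrogen, 1 selenium; no ring), on a saturated chain carbon, five bonds along the chain from an oxygen next to a carbonyl group. This is the same kind of change as that from compound 2 to compound 1, but not the same: there the place was three bonds along the chain from an oxygen on an aromatic ring, here it is five bonds along the chain from an oxygen next to a carbonyl group. Because the earlier step was a 1.7-fold lower number from compound 2 to compound 1 (0.22 log units; within the scatter), a step of about the same size is expected here, namely a 1.5-fold lower number from compound 3 to compound 4 (0.17 log units; within the scatter). On that basis compound 4 is estimated to give 1500 nM in this assay, with a range expected from 700 nM to 3500 nM.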

Compound 4, half-maximal inhibitory concentration: 851 nM
Beside the measured number, compound 4's estimate is 1.8-fold (0.25 log units) above it, and the stated range covers the measured number.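

In this assay, putting the group of 3 heavy atoms in place of the group of 4 heavy atoms, on a saturated chain carbon, five bonds along the chain from an oxygen next to a carbonyl group, gave a 2.6-fold lower number from compound 3 to compound 4 (0.41 log units; beyond the scatter). Set beside the earlier step, this one cannot be told apart from it in size, so the data are consistent with the change carrying across the two cores: the same change on two cores in this assay, a 1.7-fold lower number (0.22 log units; within the scatter) from compound 2 to compound 1 and a 2.6-fold lower number (0.41 log units; beyond the scatter) from compound 3 to compound 4, 1.6-fold (0.20 log units) apart, within the scatter of two such steps. Among the compounds shown here, this does not show that the change counts for more on one core than on the other, even though only one of the two steps lies beyond the scatter, and two pairs of compounds are too few to give a rule for the whole series.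

The compounds shown leave open whether a step of this size would hold on either core for a longer chain or for a still shorter one. They also leave open how a chain ending in an amine or a carboxylic acid, or one with sulfur in place of selenium, would read in this assay, and whether the step would appear at all on other cell lines.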